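Swapping a methylpyrrolyl ketone for a hydroxyphenyl ketone

This account rests on a few compounds, and the source may have more. Where it says the series, first, only, none or still open, it means among the compounds named here.

Compound 1 `Cn1cccc1C(=O)/C=C/c1ccc2c(c1)B(O)OC2` is known only by a limit. In a toxicity assay on WI-38 cells (Homo sapiens) for cytotoxicity, read by MTT assay, with a stated time of 48 h (a higher number here means a weaker inhibitor, a lower number a stronger inhibitor), compound 1 gives > 100000 nM, which is a limit of the assay rather than a number (the limit of > 100000 nM in this assay, at which 1 of the 2 values shown sits). A second compound on the same core sits at a measured value: in this assay compound 2 `O=C(/C=C/c1ccc2c(c1)B(O)OC2)c1ccc(Cl)c(Cl)c1` gives 12500 nM. Compound 3 `O=C(/C=C/c1ccc2c(c1)B(O)OC2)c1cccc(O)c1` differs from compound 1 in one place: 3-hydroxyphenyl in place of 1-methyl-1H-pyrrol-2-yl on a carbonyl carbon. Among the compounds with values here, no measured step between two compounds exists here to guide the size of this change. The expected step of an at least 2.0-fold lower number from compound 1 to compound 3 (0.30 log units; that floor lies within the scatter) is modest, toward a weaker reading. Compound 3 is estimated at 50000 nM, within 15000 nM to 150000 nM.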

Compound 3, half-maximal inhibitory concentration: 26400 nM
For compound 3 the middle estimate is 1.9-fold (0.28 log units) above the measured one; the measured number falls inside the stated range.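

At this position on a carbonyl carbon, the ring carried there does shift the reading: in this assay, 3-hydroxyphenyl in place of 1-methyl-1H-pyrrol-2-yl gives an at least 3.7-fold lower number from compound 1 to compound 3 (0.57 log units; beyond the scatter). Within the data shown here, this is the first step that can be read on the shared core. Its true size remains unknown because compound 1 gives only a limit: the limit of > 100000 nM in this assay, at which 1 of the 3 values shown sits.

This single swap changes both the ring and the hydroxy group, and the compounds shown do not separate the two. On these data alone, how a plain phenyl or a 3-aminophenyl group on the carbonyl carbon would read in this assay stays open.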